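The source may hold more compounds than are shown below. What is called first, only, known or untested is meant among the compounds shown, and "the series" means these compounds.

Working notes on the series, all values taken from an ADME assay on K562 cells (Homo sapiens) for antiproliferative activity (a higher number here means a weaker inhibitor, a lower number a stronger inhibitor), as the single read-out. Compound 1 `COc1ccc2nccc(CC[C@H]3CC[C@H](NCc4ccc(Cl)c(Cl)c4)CC3)c2c1` has the entry "not determined" (no result reported) and adds no number to the comparison. Compound 2 `COc1ccc2nccc(CC[C@H]3OC[C@H](NCc4ccc5c(n4)NC(=O)CO5)CO3)c2c1` gives 24000 nM and compound 3 `COc1ccc2nccc(CC[C@H]3CC[C@H](NCc4cc5c(cn4)OCCO5)CC3)c2c1` gives 7500 nM in the same read-out. Compound 3 holds the lower of the two numbers, which makes it the stronger inhibitor of this pair, and the gap to compound 2 lies beyond the usual scatter of repeated measurements.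

Compound 4 `COc1ccc2nccc(CC[C@H]3CC[C@H](NCc4ccc5c(n4)NC(=O)CO5)CC3)c2c1` is still unmeasured. It keeps the core of compound 3, and the change sits on a saturated chain carbon bound to an amine nitrogen: a group of 11 heavy atoms (7 carbon, 2 nitrogen, 2 oxygen; one six-membered non-aromatic ring with 2 hetero atoms, one six-membered aromatic ring with 1 hetero atom) in place of a group of 10 heavy atoms (7 carbon, 1 nitrogen, 2 oxygen; one six-membered non-aromatic ring with 2 hetero atoms, one six-membered aromatic ring with 1 hetero atom), on a saturated chain carbon bound to an amine nitrogen is the whole difference between them.

Within the data shown here, no step between measured compounds isolates this change, so any expectation rests on thin ground. Among the measured compounds shown here, the only measured compound carrying the entering group is compound 2 (24000 nM) and it stands at the higher number. A modest rise toward a weaker inhibitor is therefore expected, near the edge of the scatter or somewhat beyond it. The expected step is a 1.9-fold higher number from compound 3 to compound 4 (0.27 log units; within the scatter) on this reading. Compound 4 is estimated at 14000 nM with an expected range from 5000 nM to 40000 nM for the coming measurement.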

Compound 4, half-maximal inhibitory concentration: 12000 nM
Compound 4: middle estimate off by 1.2-fold (0.07 log units), on the high side, within the range that was stated.
By their numbers in this assay, from the lowest: compounds 3, 4 and 2 (each within the scatter of the next, the first and the last beyond it).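

In this assay, among these compounds, this is the first direct reading of a change on a saturated chain carbon bound to an amine nitrogen: a 1.6-fold higher number from compound 3 to compound 4 (0.20 log units; within the scatter). The group of 11 heavy atoms brings 1 hydrogen-bond donor and 1 double bond outside aromatic rings, where the group of 10 heavy atoms has 0 hydrogen-bond donors, yet this exchange does not separate the two compounds beyond the scatter, so the read-out gives no ground for preferring either group at this place. No measured property of either group bears on the result, and no explanation for it can be offered from the data at hand.

As far as these compounds go, only these two closely sized groups can be compared at this place, so it remains open how the read-out would respond to a markedly different group there, such as a morpholine, a carboxylic acid or a longer alkyl chain. It also remains open whether the same exchange would give a similar step on the core of compound 2, where the compounds shown offer no matching partner.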